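The source may report more compounds than this note shows. Statements on the series, on what has been measured and on what is new or still open speak of the compounds shown alone.

Of the compounds shown here, two built on a shared core have so far been measured in a functional assay on NCI-H1299 cells (Homo sapiens) for inhibition, read by CCK-8 assay, with a stated time of 72 h, tested at 10 uM; a lower number here means a weaker effect, a higher number a stronger effect of the compound at the concentration tested. Compound 1 `CN(C)C(=O)c1cc2cnc(Nc3ccc(S(=O)(=O)NCCCN=C=S)cc3)nc2n1C1CCCC1` gives 72.8% in this assay, the higher of the two numbers. Compound 2 `CN(C)C(=O)c1cc2cnc(Nc3ccc(C(=O)NCCCCCCCN=C=S)cc3F)nc2n1C1CCCC1` gives 35.8% in this assay, a number beyond the usual scatter below that of compound 1; the two differ in more than one place, so their gap cannot be tied to any single change. Compound 3 `CN(C)C(=O)c1cc2cnc(Nc3ccc(NC(=O)CCCCCN=C=S)cc3)nc2n1C1CCCC1` has not yet been measured. It is related to compound 1 by a change on an aromatic carbon of a six-membered aromatic ring of carbon only, para to a large group: a group of 11 heavy atoms (7 carbon, 2 nitrogen, 1 oxygen, 1 sulfur; no ring) in place of a group of 10 heavy atoms (4 carbon, 2 nitrogen, 2 oxygen, 2 sulfur; no ring), on an aromatic carbon. Going by the values given here, no pair of measured compounds differing in one place exists here, so there is no direct precedent for this change. The author expects the step from compound 1 to compound 3 to be a moderate loss, a number 17.8 percentage points lower from compound 1 to compound 3 (beyond the scatter). Compound 3 is estimated at 55%, with a range from 30% to 78%.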

Compound 3, a percentage reported as inhibition, at one concentration (the size of the read-out at that concentration, not a potency): 85%
The estimate for compound 3 lay 30 percentage points below the measured number; measured number outside the range, above it.
By their numbers in this assay, from the lowest: compound 2; then compound 1; then compound 3.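

Going by these compounds alone, at the aromatic carbon para to a large group, this assay now gives a first reading of a single change: the group of 11 heavy atoms in place of the group of 10 heavy atoms is a step of a number 12.2 percentage points higher from compound 1 to compound 3 (beyond the scatter). The whole side group at this place can therefore be exchanged without losing the effect at the concentration tested, even though the entering group has 3 hydrogen-bond acceptors rather than 4. Nothing available explains this rise.

The step changes the link to the ring and the chain length together, so the compounds shown cannot separate these two parts. On these data alone, whether a longer chain would keep the effect, or an amine or a carboxylic acid in place of the terminal isothiocyanate, remains open.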